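Extending the Amide Side Chain: Compound 2 to Compound 4

The compounds below may be only part of what the source reports. "The series", "measured", "known", "first", "only" and "open" are said of these compounds alone.

Three measured compounds share one core and differ only in the group on the amide-type nitrogen. Compound 1 `CCN(CC)CCNC(=O)c1ccc(C(CC)(CC)c2ccc(OCS(=O)(=O)c3ccccc3)c(C)c2)n1CC` carries a 2-(diethylamino)ethyl group, and in a functional assay on MCF7 cells (Homo sapiens) for antiproliferative activity, read by MTT assay, with a stated time of 24 h (a higher number here means a weaker inhibitor, a lower number a stronger inhibitor), compound 1 gives 4680 nM. Compound 2 `CCn1c(C(=O)N[C@@H](C)CO)ccc1C(CC)(CC)c1ccc(OCS(=O)(=O)c2ccccc2)c(C)c1` carries a 1-(hydroxymethyl)ethyl group instead, and in this assay compound 2 gives 10800 nM. Compound 3 `CCn1c(C(=O)N[C@@H](CO)C(C)C)ccc1C(CC)(CC)c1ccc(OCS(=O)(=O)c2ccccc2)c(C)c1` carries a 1-(hydroxymethyl)-2-methylpropyl group, and in this assay compound 3 gives 18800 nM. Among these three numbers compound 2 stands second highest: the step of a 2.3-fold higher number from compound 1 to compound 2 (0.36 log units; beyond the scatter) is beyond the scatter, whereas the step of a 1.7-fold higher number from compound 2 to compound 3 (0.24 log units; within the scatter) is within it.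

Compound 4 `CCn1c(C(=O)N[C@H](CO)CCCO)ccc1C(CC)(CC)c1ccc(OCS(=O)(=O)c2ccccc2)c(C)c1` has not yet been measured. It differs from compound 2 by 2-hydroxyethyl in place of hydrogen on a saturated chain carbon, two bonds along the chain from an amide-type nitrogen. The step that bears most on this change is a 1.7-fold higher number from compound 2 to compound 3 (0.24 log units; within the scatter), where enlarging the group on the amide-type nitrogen left the number within the scatter, and the step of a 4.0-fold higher number from compound 1 to compound 3 (0.60 log units; beyond the scatter) shows that even a larger change on this nitrogen moved the number only modestly. Little movement is therefore expected for compound 4, and any shift is expected to be towards a higher number. Compound 4 is expected to give about 13000 nM, with a range from 5500 nM to 32000 nM, an expected step of a 1.2-fold higher number from compound 2 to compound 4 (0.08 log units; within the scatter).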

Compound 4, half-maximal inhibitory concentration: 31400 nM
For compound 4 the middle estimate is 2.4-fold (0.38 log units) below the measured one; the measured number falls inside the stated range.
By their numbers in this assay, from the lowest: compound 1; then compounds 2, 3 and 4 (each within the scatter of the next, the first and the last beyond it).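

Within the data shown here, at this place the result is clearer than the earlier steps suggested: 2-hydroxyethyl in place of hydrogen on the saturated chain carbon, two bonds along the chain from the amide-type nitrogen, gives a 2.9-fold higher number from compound 2 to compound 4 (0.46 log units; beyond the scatter) in this assay, so this change moves the number beyond the scatter. Compound 4 still cannot be separated from the compound with the 1-(hydroxymethyl)-2-methylpropyl group (a 1.7-fold higher number from compound 3 to compound 4 (0.22 log units; within the scatter)), so two different additions at this carbon end up within the scatter of each other. The distance from the 2-(diethylamino)ethyl group also grows to a 6.7-fold higher number from compound 1 to compound 4 (0.83 log units; beyond the scatter), and among these four compounds all three side chains that end in a hydroxyl stay beyond the scatter from compound 1.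

The compounds shown cannot separate the effect of the added chain from that of its end hydroxyl; a plain propyl chain on this carbon, or an amine or a carboxylic acid at the end of the 2-hydroxyethyl chain, would bear directly on that question. Nothing given here offers an explanation for the size of this step.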